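The source may report more compounds than this note shows. Statements on the series, on what has been measured and on what is new or still open speak of the compounds shown alone.

Measured so far in a functional assay with Rattus norvegicus as the target; on this read-out lower numbers stand for an effect already at smaller amounts and higher numbers for an effect only at larger amounts of compound:
compound 1 `CC1(C)C=C(n2ccccc2=O)c2cc(S(=O)(=O)N=[N+]=[N-])ccc2O1`, 204 nM
compound 2 `CNS(=O)(=O)c1ccc2c(c1)C(n1ccccc1=O)=CC(C)(C)O2`, 138 nM
compound 3 `CC1(C)C=C(n2ccccc2=O)c2cc(S(=O)(=O)Nc3ccc(C#N)cc3)ccc2O1`, 1380 nM

Compound 1 stands second highest of the three numbers; the nearest step away from it is a 1.5-fold lower number from compound 1 to compound 2 (0.17 log units; within the scatter) and the furthest is a 6.8-fold higher number from compound 1 to compound 3 (0.83 log units; beyond the scatter). Compound 4 `CN(c1ccccc1)S(=O)(=O)c1ccc2c(c1)C(n1ccccc1=O)=CC(C)(C)O2` is not yet measured; against compound 1 the change is methyl(phenyl)amino in place of azido on a sulfonyl sulfur. Among the measured compounds shown here, two measured steps bear on it. Swapping azido for methylamino stayed within the scatter, while putting an aryl group on the sulfonamide nitrogen raised the number, a 10-fold higher number from compound 2 to compound 3 (1.00 log units; beyond the scatter). For the measured compounds named here, compound 4 carries a phenyl on that nitrogen as well, and no measured pair tells how the missing nitrile matters. A modest rise is therefore expected, a 2.9-fold higher number from compound 1 to compound 4 (0.47 log units; beyond the scatter). Compound 4 is estimated at 600 nM, range 250 nM to 1800 nM.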

Compound 4, half-maximal effective concentration: 9.77 nM
Compound 4: the middle estimate sits 61-fold (1.79 log units) above what was measured; the measured number lies below the stated range.
By their numbers in this assay, from the lowest: compound 4; then compounds 2 and 1 (each within the scatter of the next); then compound 3.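

Methyl(phenyl)amino on the sulfonyl sulfur gives a 21-fold lower number from compound 1 to compound 4 (1.32 log units; beyond the scatter), so in this assay the larger group at this position can lower the number and not only raise it. An aryl group on the sulfonamide nitrogen does not raise the number by itself: a 14-fold lower number from compound 2 to compound 4 (1.15 log units; beyond the scatter), whereas compound 3 went the other way, and the gap between the two aryl compounds is a 140-fold lower number from compound 3 to compound 4 (2.15 log units; beyond the scatter).

On these data alone, compounds 3 and 4 differ in both the nitrile and the nitrogen methyl, so neither can be credited alone, and how benzyl or morpholine on the sulfonyl sulfur would read remains open. Nothing available accounts for these steps.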